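Swapping the Ring Substituent: Cytotoxicity in HEL Cells

The source may report more compounds than this note shows. Statements on the series, on what has been measured and on what is new or still open speak of the compounds shown alone.

Measured compounds:
compound 1 `O=C(COc1cccc2ccccc12)N/N=C/c1cccc(Br)c1`, 48.6 ug/mL
compound 2 `COc1ccc(/C=N/NC(=O)COc2cccc3ccccc23)cc1`, 100 ug/mL

Two compounds share a common core and differ only in the aromatic ring attached to a carbon with a double bond to nitrogen. In an ADME assay on HEL cells (Homo sapiens) for cytotoxicity (on this read-out lower numbers stand for higher toxicity in this test and higher numbers for lower toxicity in this test), compound 1 gives 48.6 ug/mL, while compound 2 gives 100 ug/mL, the highest of the two numbers. Within the data shown here, the one measured step, a 2.1-fold higher number from compound 1 to compound 2 (0.31 log units; beyond the scatter), shows that exchanging 3-bromophenyl for 4-methoxyphenyl moves the number upward by a modest amount, beyond the scatter.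

Compound 3 `O=C(COc1cccc2ccccc12)N/N=C/c1cccc(Cl)c1` has not yet been measured in this assay. It differs from compound 2 as follows: 3-chlorophenyl in place of 4-methoxyphenyl on a carbon with a double bond to nitrogen. This change is close to reversing the measured step, since 3-chlorophenyl resembles the 3-bromophenyl of compound 1 more than the 4-methoxyphenyl of compound 2. The step from compound 1 to compound 2 is therefore the one that bears on it, and a downward move of similar size is expected, a 1.8-fold lower number from compound 2 to compound 3 (0.26 log units; within the scatter). On that basis compound 3 is estimated at 55 ug/mL, with a likely range from 30 ug/mL to 100 ug/mL.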

Compound 3, half-maximal cytotoxic concentration: 58.6 ug/mL
Beside the measured number, compound 3's estimate is 1.1-fold (0.03 log units) below it; measured number inside the range.
By their numbers in this assay, from the lowest: compounds 1, 3 and 2 (each within the scatter of the next, the first and the last beyond it).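

In this assay, among these compounds, the exchange of bromo for chloro on an aromatic carbon is the first comparison in which only the halogen changes, and the result is a 1.2-fold higher number from compound 1 to compound 3 (0.08 log units; within the scatter), so this swap has no readable effect on the number. The exchange of 4-methoxyphenyl for 3-chlorophenyl on a carbon with a double bond to nitrogen gives a 1.7-fold lower number from compound 2 to compound 3 (0.23 log units; within the scatter), so, unlike the exchange involving 3-bromophenyl, it does not clear the usual scatter, and the separation between the halogen-bearing and methoxy-bearing compounds is therefore not firm. No measurement available here explains these numbers.

The compounds shown leave open whether the small differences at this position follow the identity of the group or where it sits on the ring, a question that a 3-methoxyphenyl or 4-chlorophenyl group could help to settle. They also leave open whether the number would move clearly beyond the scatter with a very different group on the phenyl ring, such as an amine or a carboxylic acid.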